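Carrying a Methyl Step Over to a Second Core

The source may report more compounds than this note shows. Statements on the series, on what has been measured and on what is new or still open speak of the compounds shown alone.

Compound 1 `CC/C=C/C(=O)Nc1cc2c(N3CCCc4ccccc43)ncnc2cc1OC` and compound 2 `CCC/C=C/C(=O)Nc1cc2c(N3CCCc4ccccc43)ncnc2cc1OC` share one core; compound 3 `CC/C=C/C(=O)Nc1cc2c(N3CCCc4ccccc43)ncnc2cc1O[C@@H]1CCOC1` and compound 4 `CC(C)/C=C/C(=O)Nc1cc2c(N3CCCc4ccccc43)ncnc2cc1O[C@@H]1CCOC1` share another, and the two cores differ by oxolan-3-yl in place of methyl on an oxygen on an aromatic ring. In a functional assay on PC-3 cells (Homo sapiens) for antiproliferative activity, read by MTT assay, with a stated time of 72 h (a higher number here means a weaker inhibitor, a lower number a stronger inhibitor), compound 1 gives 6310 nM, compound 2 gives 2240 nM and compound 3 gives 14300 nM. The change from compound 1 to compound 2, (methyl in place of hydrogen on a saturated chain carbon, two bonds along the chain from a double-bonded chain carbon), brought a 2.8-fold lower number from compound 1 to compound 2 (0.45 log units; beyond the scatter). The change from compound 3 to compound 4, (methyl in place of hydrogen on a saturated chain carbon bound to a double-bonded chain carbon and a saturated chain carbon), is the same kind of change, but the place differs: in the first pair the methyl enters on a saturated chain carbon two bonds along the chain from a double-bonded chain carbon, in the second on a saturated chain carbon bound to a double-bonded chain carbon and a saturated chain carbon. Resting on that single earlier step, compound 4 is expected to show a 2.0-fold lower number from compound 3 to compound 4 (0.31 log units; beyond the scatter), of about the same modest size. Compound 4 is therefore estimated at 7000 nM, in a range from 3000 nM to 20000 nM.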

Compound 4, half-maximal inhibitory concentration: 8510 nM
For compound 4 the middle estimate is 1.2-fold (0.08 log units) below the measured one; the measured number falls inside the stated range.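

In this assay, the methyl step on the second core gave a 1.7-fold lower number from compound 3 to compound 4 (0.23 log units; within the scatter), so on this core alone the step cannot be told apart from the scatter of repeated measurements. Set beside the earlier step on the first core, it shows no detectable difference between the two cores: the same change on two cores in this assay, a 2.8-fold lower number (0.45 log units; beyond the scatter) from compound 1 to compound 2 and a 1.7-fold lower number (0.23 log units; within the scatter) from compound 3 to compound 4, 1.7-fold (0.22 log units) apart, within the scatter of two such steps. This rests on a single pair per core, with the methyl entering at a different place in each pair, and it does not show that the change carries over unchanged to other cores in this series.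

The compounds shown leave open how an amine or a longer chain in place of the ethyl group would fare on either core. As far as these compounds go, whether the two placements of the methyl would give matching steps on one and the same core also stays open.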